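A few compounds are considered here, and "the series" means these few. Any claim that something is new, unique, unknown or untested is made for them only; others in the source may bear on it.

Measured so far:

Compound 1, `Cc1ncc2nccn2c1-c1ccc(Oc2nccc3occc23)cc1C(F)(F)F`: in an assay on cells for displacement of a labelled ligand from sodium-dependent dopamine transporter (Homo sapiens), read by scintillation counting, with a stated time of 90 min (on this read-out higher numbers stand for weaker inhibition and lower numbers for stronger inhibition), compound 1 gives > 10000 nM, which is a limit of the assay rather than a number.

Compound 2, `FC(F)(F)c1cc(Oc2nccc3occc23)ccc1-c1cccc2nccn12`: in this assay compound 2 gives 9100 nM.

Going by the values given here, compound 2 therefore stands as the only plain number in the set; the one other value shown is a limit. Among the compounds with values here, the single measured step, an at least 1.0-fold lower number from compound 1 to compound 2 (0.04 log units; that floor lies within the scatter), exchanges one fused ring system on an aromatic carbon for another, and its size is set by the limit of > 10000 nM in this assay, at which 1 of the 2 values shown sits, so it says only that the two compounds are not far apart.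

Compound 3, `FC(F)(F)c1cc(Oc2nccc3ccsc23)ccc1-c1cccc2nccn12`, differs from compound 2 in a different part of the molecule: a group of 9 heavy atoms (7 carbon, 1 nitrogen, 1 sulfur; one five-membered aromatic ring with 1 hetero atom, one six-membered aromatic ring with 1 hetero atom) in place of a group of 9 heavy atoms (7 carbon, 1 nitrogen, 1 oxygen; one five-membered aromatic ring with 1 hetero atom, one six-membered aromatic ring with 1 hetero atom), on an oxygen on an aromatic ring. Within the data shown here, no measured step touches this position, so nothing in the data points to a gain or a loss; the one step that exists moved the number little and concerned another ring. The change from compound 2 to compound 3 is expected to be a 1.0-fold lower number from compound 2 to compound 3 (0.00 log units; within the scatter), that is, no shift beyond the scatter. Compound 3 is accordingly estimated at 9000 nM, with a range from 3000 nM to 27000 nM, and a real chance that the assay again reports only a limit.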

Compound 3, inhibition constant: 4500 nM
Compound 3: the middle estimate sits 2.0-fold (0.30 log units) above what was measured, within the range that was stated.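

In this assay the group on the oxygen on an aromatic ring proves able to move the number: exchanging the oxygen atom of that group for a sulfur atom gives a 2.0-fold lower number from compound 2 to compound 3 (0.31 log units; beyond the scatter) and so counts as a modest but real shift. Going by these compounds alone, compound 2 and compound 3 both carry plain numbers, which makes this the first step in the set whose full size can be read, and it is also the first sign that this part of the molecule matters at all. The earlier step could offer only a floor, as compound 1 has just a limit: the limit of > 10000 nM in this assay, at which 1 of the 3 values shown sits.

The compounds shown do not tell why the sulfur-containing group gives the lower number, nor whether the same exchange would have a similar effect with the fused ring system of compound 1 in place. They also leave open how far this position can be pushed, for instance whether a plain phenyl ring on that oxygen, or an amine or a carboxylic acid added to the fused group, would bring the number down further or send it back up.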